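Changing the aryl group on the amide nitrogen

A few compounds are considered here, and "the series" means these few. Any claim that something is new, unique, unknown or untested is made for them only; others in the source may bear on it.

Within the data shown here, in a functional assay on A549 cells (Homo sapiens) for cytotoxicity, read by MTT assay (a lower number here means a stronger inhibitor, a higher number a weaker inhibitor), three compounds sharing one core have numbers so far. Compound 1 `CCn1cc(-c2nc3ccc([N+](=O)[O-])cc3o2)c(=O)c2cc(F)c(N3CCNC(C)C3)c(F)c21` gives 900 nM, compound 2 `CCn1cc(C(=O)Nc2ccccc2O)c(=O)c2cc(F)c(N3CCNC(C)C3)c(F)c21` gives 24800 nM, and compound 3 `CCn1cc(C(=O)Nc2cc([N+](=O)[O-])ccc2F)c(=O)c2cc(F)c(N3CCNC(C)C3)c(F)c21` gives 1700 nM. Compound 3 therefore lies within the scatter of compound 1 and far from compound 2. Among the measured compounds shown here, the one measured step between these compounds, a 15-fold lower number from compound 2 to compound 3 (1.16 log units; beyond the scatter), is large and comes from 2-fluoro-5-nitrophenyl replacing 2-hydroxyphenyl on an amide-type nitrogen.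

Compound 4 `CCn1cc(C(=O)Nc2ccc(OC(F)(F)F)cc2)c(=O)c2cc(F)c(N3CCNC(C)C3)c(F)c21` changes the same place, with 4-(trifluoromethoxy)phenyl in place of 2-fluoro-5-nitrophenyl on an amide-type nitrogen. The measured step of a 15-fold lower number from compound 2 to compound 3 (1.16 log units; beyond the scatter) shows that the number can move strongly with the group at this place. It involves neither the group that enters here nor any comparable pair, so it gives no direction for the new change. For the measured compounds named here, the data hold no compound carrying 4-(trifluoromethoxy)phenyl. The expectation is therefore for no step beyond the scatter, with wide uncertainty in both directions. The estimated change is a 1.8-fold higher number from compound 3 to compound 4 (0.25 log units; within the scatter). For compound 4 the estimate is 3000 nM, with an expected range of 900 nM to 11000 nM.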

Compound 4, half-maximal inhibitory concentration: 1320 nM
The estimate for compound 4 lay 2.3-fold (0.36 log units) above the measured number, within the range that was stated.
By their numbers in this assay, from the lowest: compounds 1, 4 and 3 (each within the scatter of the next); then compound 2.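

In this assay, putting 4-(trifluoromethoxy)phenyl in place of 2-fluoro-5-nitrophenyl on the amide-type nitrogen gives a 1.3-fold lower number from compound 3 to compound 4 (0.11 log units; within the scatter), so these two differently substituted aryl groups cannot be told apart at this position. Measured against 2-hydroxyphenyl, the new group gives a 19-fold lower number from compound 2 to compound 4 (1.27 log units; beyond the scatter), which shows that the large step seen earlier, a 15-fold lower number from compound 2 to compound 3 (1.16 log units; beyond the scatter), is not confined to the 2-fluoro-5-nitrophenyl group: among the three amides shown, compound 2 alone stands apart, while compound 3 and compound 4 sit together. No supporting measurement is available to explain why these aryl groups read alike or why compound 2 differs from them.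

As far as these compounds go, it remains open whether an unsubstituted phenyl, a benzyl group or a simple butyl chain on the same amide-type nitrogen would read like compound 3 and compound 4 or like compound 2. The compounds shown also leave open whether an aryl ring carrying an amine or a carboxylic acid would fall near compound 2, at 24800 nM, or stay with the other two amides.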